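The source may hold more compounds than are shown below. What is called first, only, known or untested is meant among the compounds shown, and "the series" means these compounds.

In a functional assay on the whole organism (stomach) with Rattus norvegicus as the target (a lower number here means that less compound is needed, a higher number that more compound is needed for the effect), compound 1 `C/N=C(/NC#N)NCCCn1nc(-c2ccccc2)ccc1=O` reaches only the limit of the assay, giving > 100 mg/kg. Compound 2 `O=c1ccc(-c2ccccc2)nn1CCCCNC(=S)Nc1ccc(Cl)cc1` likewise stops at a limit, > 100 mg/kg. Compound 3 `C/N=C(/NC#N)NCCCCn1nc(N(C)C)ccc1=O` too shows nothing more than a limit, > 100 mg/kg. All three values sit at the limit of > 100 mg/kg in this assay, at which 3 of the 3 values shown sit, so compound 3 stands nowhere apart from the other two. Compound 4 `C/N=C(/NC#N)NCCCCn1nc(-c2ccc(Cl)cc2)ccc1=O` is not yet measured; it differs from compound 3 by 4-chlorophenyl in place of dimethylamino on an aromatic carbon. For the measured compounds named here, no pair of measured compounds separated by a single change is available, so the step can be judged only from these limits. Compound 1 also carries a phenyl ring and still gives only the limit > 100 mg/kg. The step that the limit leaves unreadable from compound 3 to compound 4 is therefore expected to be small, with no direction beyond the scatter. Compound 4 is expected to give about 150 mg/kg, between 50 mg/kg and 600 mg/kg, most likely again only as a limit.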

Compound 4, dose for half-maximal effect: 100 mg/kg
Compound 4: the middle estimate sits 1.5-fold (0.18 log units) above what was measured; measured number inside the range.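

With 4-chlorophenyl in place of dimethylamino on this aromatic carbon, the series shows a number no higher from compound 3 to compound 4 (the limit leaves the size open). Compound 4 is therefore the only compound shown that gives a number rather than a limit in this assay, although the size of the step cannot be read. The other values stay at the edge of the assay: the limit of > 100 mg/kg in this assay, at which 3 of the 4 values shown sit.

Going by these compounds, it remains open whether 4-fluorophenyl or morpholine at this position would also give a number. The effect of a longer chain on compound 4 is open as well.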